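Methylsulfonyl to acetyl on the aminopyridine nitrogen

This account rests on a few compounds, and the source may have more. Where it says the series, first, only, none or still open, it means among the compounds named here.

Measured compounds:
compound 1, `C[C@H](NC(=O)c1cccc(-c2ccc(NS(C)(=O)=O)nc2)c1)C(=O)Nc1ccc(Cl)c(C(F)(F)F)c1` — 4660 nM
compound 2, `CC(=O)Nc1ccc(-c2cccc(C(=O)N[C@H]3CN[C@@H](C(=O)Nc4ccc(Cl)c(C(F)(F)F)c4)C3)c2)cn1` — 8710 nM
compound 3, `CC(=O)Nc1ccc(-c2ccc(C(=O)N[C@H]3CN[C@@H](C(=O)Nc4ccc(Cl)c(C(F)(F)F)c4)C3)cc2)cn1` — 22800 nM

In a functional assay on K562 cells (Homo sapiens) for inhibition, read by MTT assay, with a stated time of 48 h (on this read-out higher numbers stand for weaker inhibition and lower numbers for stronger inhibition), compound 1 gives the lowest of the three numbers. Compound 2 gives 8710 nM, which is within the scatter of compound 1. Compound 3 gives 22800 nM, a gap from compound 1 that is beyond the scatter. Compounds 2 and 3 both carry an acetamido group on the pyridine, but on a different core, so neither offers a one-change step to compound 1.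

Compound 4 is `CC(=O)Nc1ccc(-c2cccc(C(=O)N[C@@H](C)C(=O)Nc3ccc(Cl)c(C(F)(F)F)c3)c2)cn1`. It keeps the core of compound 1 and differs only in acetyl in place of methylsulfonyl on a nitrogen on an aromatic ring. Among the compounds with values here, no measured pair isolates this change. With acetamido compounds 2 and 3 sitting near or above compound 1, the step is expected to be small, at most a modest weakening, and a 1.4-fold higher number from compound 1 to compound 4 (0.14 log units; within the scatter) is the estimate taken here, not clearly beyond the scatter.

For compound 4 in this assay the expected value is 6500 nM, with a range of 2500 nM to 17000 nM.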

Compound 4, half-maximal inhibitory concentration: 42800 nM
Compound 4: middle estimate off by 6.6-fold (0.82 log units), on the low side; measured number above the stated range.
By their numbers in this assay, from the lowest: compounds 1 and 2 (each within the scatter of the next); then compounds 3 and 4 (each within the scatter of the next).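

In this assay, methanesulfonamido to acetamido gives a 9.2-fold higher number from compound 1 to compound 4 (0.96 log units; beyond the scatter) with the core of compound 1 held constant, so the group on this nitrogen on an aromatic ring is not freely interchangeable in this series. Within this pair, the methylsulfonyl group goes with the lower number and the acetyl group with the higher one, a single-change reading that compounds 2 and 3, on a different core, could not give. No measurement shown here accounts for the size of this step.

One pair cannot tell whether the step is specific to these two groups, or how a free amine or an ethylsulfonyl group on the same nitrogen would read on this core. On these data alone, whether the step carries over to the core of compounds 2 and 3 also stays open.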